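A few compounds are considered here, and "the series" means these few. Any claim that something is new, unique, unknown or untested is made for them only; others in the source may bear on it.

Values measured so far in a functional assay on B16-F10 cells (Mus musculus) for antiproliferative activity, read by MTT assay, with a stated time of 48 h (a lower number here means a stronger inhibitor, a higher number a weaker inhibitor), are these
Compound 1 `COc1ccc(/C=C/C(=O)Nc2cc(-c3ccc(Br)cc3)[nH]n2)cc1` gives 770 nM
Compound 2 `O=C(/C=C/c1ccc(Br)cc1)Nc1cc(-c2ccc(Br)cc2)[nH]n1` gives 1280 nM

Going by the values given here, compound 2 stands within the usual scatter of compound 1, the only other compound measured, so the two cannot be ranked against each other. Among the compounds with values here, the single measured step reads a 1.7-fold higher number from compound 1 to compound 2 (0.22 log units; within the scatter) and puts bromo in place of methoxy on an aromatic carbon.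

Compound 3 `O=C(/C=C/c1ccc(Cl)cc1)Nc1cc(-c2ccc(Br)cc2)[nH]n1` changes compound 2 in one group only chloro in place of bromo on an aromatic carbon and so carries chloro in place of bromo on an aromatic carbon, para to a large group. This exact swap has not been measured, and the evidence for it is thin. Even so, the one step at this same place stayed within the scatter, and it is the only guide available. A change from bromo to chloro is therefore expected to give no shift beyond the scatter in this assay here.

The estimated move is a 1.2-fold lower number from compound 2 to compound 3 (0.07 log units; within the scatter) and is expected to be too small to read as a real difference. For compound 3 the expected value is 1100 nM with an estimated range from 550 nM to 2200 nM in this assay.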

Compound 3, half-maximal inhibitory concentration: 1080 nM
The estimate for compound 3 lay 1.0-fold (0.01 log units) above the measured number, within the range that was stated.
By their numbers in this assay, from the lowest: compounds 1, 3 and 2 (each within the scatter of the next).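

In this assay, putting chloro in place of bromo on this aromatic carbon gives a 1.2-fold lower number from compound 2 to compound 3 (0.07 log units; within the scatter), and comparing chloro with methoxy at the same place gives a 1.4-fold higher number from compound 1 to compound 3 (0.15 log units; within the scatter). Where the earlier compounds offered a single pair, there are now three groups at this place, para to a large group, and methoxy, bromo and chloro all lie within the usual scatter of one another, so this assay does not tell them apart and no ranking among compounds 1, 2 and 3 can be drawn. No separate measurement is available to explain this flat reading.

The compounds shown leave open whether a quite different group on this aromatic carbon, such as an amine, a carboxylic acid or a longer chain, would move the number beyond the scatter. All three compounds also share one core, and whether these swaps would read the same way on a different core remains an open question.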